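The source may report more compounds than this note shows. Statements on the series, on what has been measured and on what is new or still open speak of the compounds shown alone.

Measured so far:
compound 1 `CCOC(=O)C(=O)Nc1cccccc1=O`: 79%
compound 2 `CCOC(=O)C(=O)Nc1c(C)ccccc1=O`: 4%

In a functional assay on the whole organism (strain Sprague-Dawley CD) for inhibition, with Rattus norvegicus as the target, read by paw edema, at a dose of 30 mg/kg by the oral route (a lower number here means a weaker effect, a higher number a stronger effect of the compound at the dose given), compound 1 gives 79%, the highest of the two numbers; compound 2 gives 4%. Among the compounds with values here, the one step is a number 75 percentage points lower from compound 1 to compound 2 (beyond the scatter), beyond the scatter. Compound 3 `CCOC(=O)C(=O)Nc1ccccc(C)c1=O` is not yet measured. It differs from compound 1 by methyl in place of hydrogen on an aromatic carbon. Within the data shown here, the only precedent for a methyl entering an aromatic carbon of this core is that large fall, though compound 2 carries its methyl on a different ring carbon, so the size of the effect here is uncertain. A drop in this assay is expected, smaller than the measured one. Compound 3 is estimated at 35%, range 0% to 75%. The expected step is a number 44 percentage points lower from compound 1 to compound 3 (beyond the scatter).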

Compound 3, a percentage reported as inhibition, in the whole organism at one dose (the size of the read-out at that dose, not a potency): 6%
Estimate against measurement, compound 3: 29 percentage points above; the range from low to high includes it.
By their numbers in this assay, from the lowest: compounds 2 and 3 (each within the scatter of the next); then compound 1.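

In this assay, methyl in place of hydrogen on this aromatic carbon, two ring bonds from the ring atom that bears the group of 8 heavy atoms, gives a number 73 percentage points lower from compound 1 to compound 3 (beyond the scatter), so the large loss seen with compound 2 is not confined to one ring carbon. Compound 2 at 4% and compound 3 at 6% lie within the scatter of each other. Nothing available bears on the reason for this loss.

Open, from the compounds shown here alone, is whether a group other than methyl here, such as a fluorine atom, a hydroxyl or an amine, keeps the effect of compound 1.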